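This account rests on a few compounds, and the source may have more. Where it says the series, first, only, none or still open, it means among the compounds named here.

Of the compounds shown here, three from one series have been measured in an ADME assay on HepG2 cells (Homo sapiens) for inhibition, with a stated time of 48 h; on this read-out lower numbers stand for an effect already at smaller amounts and higher numbers for an effect only at larger amounts of compound. Compound 1 `CNc1nc(Nc2ccc(OC)cc2)nc2ccccc12` gives 26100 nM. For the measured compounds named here, compound 2 `CNc1nc(Nc2ccc(F)cc2)nc2ccccc12` gives 16200 nM, and the only single-point step here, a 1.6-fold lower number from compound 1 to compound 2 (0.21 log units; within the scatter), shows how little that change mattered. Compound 3 `Brc1ccc(Nc2nc(NCc3ccco3)c3ccccc3n2)cc1` gives 19000 nM; its number sits among the three within the usual scatter of both compound 2 and compound 1, so nothing separates them.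

Compound 4 `COC(=O)c1ccc(Nc2nc(NCc3ccco3)c3ccccc3n2)cc1` has not yet been measured. It differs from compound 3 in one place: methoxycarbonyl in place of bromo on an aromatic carbon. Going by the values given here, only the step from compound 1 to compound 2 bears on this, since it also swaps one group for another on an aromatic carbon of the same ring, and that step stayed within the scatter. Among the compounds with values here, no measured step shows what a methoxycarbonyl group does, so the expectation rests on that single, small precedent.

For compound 4 the step of a 1.1-fold higher number from compound 3 to compound 4 (0.02 log units; within the scatter) is therefore expected to be small, with no clear direction beyond the scatter. The estimate for compound 4 in this assay is 20000 nM, with a range from 7000 nM to 60000 nM.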

Compound 4, half-maximal effective concentration: 33500 nM
Estimate against measurement, compound 4: 1.7-fold (0.22 log units) below; the measured number falls inside the stated range.
By their numbers in this assay, from the lowest: compounds 2, 3, 1 and 4 (each within the scatter of the next, the first and the last beyond it).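

In this assay, replacing bromo with methoxycarbonyl gives a 1.8-fold higher number from compound 3 to compound 4 (0.25 log units; within the scatter) and so adds a second single-place change on this aromatic ring to the earlier one, which swapped methoxy for fluoro in a different pair of compounds. This position, para to a large group, therefore accepts a group of four heavy atoms, with two hydrogen-bond acceptors and a double bond outside the aromatic rings, in place of a single bromine without a shift that can be told from the usual scatter of the assay. No available measurement gives any property of these two groups or any other information that could account for this small step.

For the compounds shown here, it remains open whether an amine, a carboxylic acid or a longer alkyl chain at this same position would move the number beyond the scatter, since bromo and methoxycarbonyl are the only two groups compared here with this side chain on the core. From the compounds shown here alone, it is also open whether methoxycarbonyl would give a similarly small step in compounds carrying the methylamino group of compound 1 on the core.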